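Furan-3-yl versus substituted phenyl on the shared core

The compounds below may be only part of what the source reports. "The series", "measured", "known", "first", "only" and "open" are said of these compounds alone.

Measured so far in a functional assay on K562 cells (Homo sapiens) for antiproliferative activity, with a stated time of 72 h; a higher number here means a weaker inhibitor, a lower number a stronger inhibitor:
- compound 1 `Nc1ncnn2c([C@@H]3O[C@H](CO)[C@@H](O)[C@H]3O)cc(-c3ccc(F)cc3F)c12` gives 69700 nM as its value
- compound 2 `Nc1ncnn2c([C@@H]3O[C@H](CO)[C@@H](O)[C@H]3O)cc(-c3ccoc3)c12` gives 2100 nM as its value

Compound 2 holds the lower of the two numbers, so it is the stronger inhibitor of the pair. Compound 3 `Nc1ncnn2c([C@@H]3O[C@H](CO)[C@@H](O)[C@H]3O)cc(-c3ccccc3Cl)c12` is still to be measured and carries 2-chlorophenyl in place of furan-3-yl on an aromatic carbon. For the measured compounds named here, only one measured step bears on this: a 33-fold lower number from compound 1 to compound 2 (1.52 log units; beyond the scatter) is large and beyond the scatter, with furan-3-yl in place of 2,4-difluorophenyl at the same place. The new change runs the other way, from furan-3-yl back to a halogen-bearing phenyl like that of compound 1 at 69700 nM, so a large step to a higher number is expected in this assay. Going by the values given here, one pair is thin support, and 2-chlorophenyl itself has no measured precedent here. The expected move is a 7.1-fold higher number from compound 2 to compound 3 (0.85 log units; beyond the scatter) on this estimate. For compound 3 the estimated value is 15000 nM, with an expected range from 3000 nM to 70000 nM as the working estimate.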

Compound 3, half-maximal inhibitory concentration: > 100000 nM
Compound 3 ended at the assay's limit (the forecaster's own chance of this, stated with the estimate: 10%); middle value at least 6.6-fold (0.82 log units) away from the limit.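

In this assay compound 3 gives > 100000 nM, which is a limit of the assay and not a number: the limit of > 100000 nM in this assay, at which 1 of the 3 values shown sits.

Even read as a limit, 2-chlorophenyl in place of furan-3-yl gives an at least 47-fold higher number from compound 2 to compound 3 (1.67 log units; beyond the scatter), so the large gap first seen with 2,4-difluorophenyl is not confined to that one group, and both halogen-bearing phenyl groups now stand as much weaker inhibitors than furan-3-yl at this position on the five-membered aromatic ring. Between the two phenyl groups the data give only an at least 1.4-fold higher number from compound 1 to compound 3 (0.15 log units; that floor lies within the scatter), and with that floor inside the scatter no order of compound 1 and compound 3 can be stated.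

Still open, on these data alone, is whether the gap to compound 2 follows the six-membered aromatic ring itself or its halogens, a question that unsubstituted phenyl would address, while thiophen-3-yl would test how far the activity of compound 2 extends to another five-membered aromatic ring. The true value of compound 3 also remains unresolved, so the full size of its step from compound 2 stays undefined.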